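A few compounds are considered here, and "the series" means these few. Any claim that something is new, unique, unknown or untested is made for them only; others in the source may bear on it.

Working notes on the series. Compound 1 `C=CCOC(=O)NC[C@H]1OC(N(CC2=CC[C@@H](C(=C)C)CC2)OC)[C@H](O)[C@@H](O)[C@@H]1O` gives 232000 nM in a functional assay on PC-3 cells (Homo sapiens) for cytotoxicity, read by resazurin assay, with a stated time of 48 h; a higher number here means a weaker inhibitor, a lower number a stronger inhibitor. Compound 2 `C=C(C)[C@@H]1CC=C(CN(OC)C2OC[C@@H](N=[N+]=[N-])[C@H](O)[C@H]2O)CC1` gives 170000 nM in this assay, and compound 3 `C=C(C)[C@@H]1CC=C(CN(OC)C2O[C@H](CN=[N+]=[N-])[C@@H](O)[C@H](O)[C@H]2O)CC1` gives 182000 nM. On these three numbers compound 3 stands second highest; its nearest neighbour is compound 2 and its furthest compound 1, both gaps within the scatter. For the measured compounds named here, the one measured step, a 1.3-fold lower number from compound 1 to compound 3 (0.11 log units; within the scatter), is within the scatter. Compound 4 `C=C(C)[C@@H]1CC=C(CN(OC)C2O[C@H](CN=[N+]=[N-])[C@@H](N=[N+]=[N-])[C@H](O)[C@H]2O)CC1` carries azido in place of hydroxy on a saturated ring carbon. Going by the values given here, no measured step changes a hydroxy on the ring to azido; the step of a 1.3-fold lower number from compound 1 to compound 3 (0.11 log units; within the scatter) concerns a chain carbon and is the only guide, and it showed no change beyond the scatter. Compound 4 is therefore expected at 180000 nM, range 90000 nM to 360000 nM. The expected step is a 1.0-fold lower number from compound 3 to compound 4 (0.00 log units; within the scatter), none beyond the scatter.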

Compound 4, half-maximal inhibitory concentration: 57000 nM
Beside the measured number, compound 4's estimate is 3.2-fold (0.50 log units) above it; measured number outside the range, below it.
By their numbers in this assay, from the lowest: compound 4; then compounds 2, 3 and 1 (each within the scatter of the next).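

In this assay, azido in place of hydroxy on this saturated ring carbon gives a 3.2-fold lower number from compound 3 to compound 4 (0.50 log units; beyond the scatter), beyond the scatter, whereas the earlier azido change on a chain carbon, a 1.3-fold lower number from compound 1 to compound 3 (0.11 log units; within the scatter), stayed within it. Azidomethyl in place of hydrogen on a saturated ring carbon likewise gives a 3.0-fold lower number from compound 2 to compound 4 (0.47 log units; beyond the scatter), so both single changes leading to compound 4 lower the number by a modest step. Nothing at hand accounts for either step.

Open, from the compounds shown here alone, is whether the step follows from adding azido or from removing hydroxy. An amine or a methoxy group on this ring carbon would help separate the two.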